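The source may hold more compounds than are shown below. What is called first, only, known or untested is meant among the compounds shown, and "the series" means these compounds.

Compound 1 `CCc1ccc2oc(-c3ccc(NC(=O)Nc4cccc(Cl)c4)cc3Cl)cc(=O)c2c1` is the reference point of this set. Going by the values given here, in an ADME assay on L02 cells (Homo sapiens) for inhibition, read by MTT assay, with a stated time of 48 h, tested at 100 uM (a higher number here means a stronger effect of the compound at the concentration tested, a lower number a weaker effect), compound 1 gives 37.2%, which is the second highest of the three numbers measured so far. Compound 2 `CCc1ccc2oc(-c3ccc(NC(=O)Nc4ccc(Cl)cc4)cc3Cl)cc(=O)c2c1` gives 28.3%, and the step of a number 8.9 percentage points lower from compound 1 to compound 2 (within the scatter) stays within the scatter. Compound 3 `COc1ccc2oc(-c3ccc(NC(=O)Nc4ccc(Cl)c(Cl)c4)cc3Cl)cc(=O)c2c1` gives 77.9%, clearly higher than compound 1, but compound 3 differs from compound 1 in two places at once, so no single step can be read from that pair.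

Compound 4 `O=C(Nc1cccc(Cl)c1)Nc1ccc(-c2cc(=O)c3cc(F)ccc3o2)c(Cl)c1` is the next candidate: fluoro in place of ethyl on an aromatic carbon. Among the compounds with values here, the only measured single step, from compound 1 to compound 2, alters the chlorophenyl on the urea nitrogen and not the substituent on the fused ring, so it does not bear directly on this change; no measured pair isolates the group on the aromatic carbon of the fused system. In the absence of such a guide, no step beyond the scatter is expected, and the expected step of a number 2.8 percentage points higher from compound 1 to compound 4 (within the scatter) is small. The estimate for compound 4 in this assay is therefore 40%, within 15% to 70%.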

Compound 4, a percentage reported as inhibition, at one concentration (the size of the read-out at that concentration, not a potency): 54.2%
Compound 4: middle estimate off by 14.2 percentage points, on the low side, and the stated range covers the measured number.
By their numbers in this assay, from the lowest: compounds 2 and 1 (each within the scatter of the next); then compound 4; then compound 3.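

In this assay, the group on this aromatic carbon of the fused system proves able to shift the read-out: fluoro in place of ethyl gives a number 17 percentage points higher from compound 1 to compound 4 (beyond the scatter) and is the only single step shown that lies beyond the scatter. The step on the chlorophenyl of the amide-type nitrogen, a number 8.9 percentage points lower from compound 1 to compound 2 (within the scatter), did not leave the scatter, so this position is the only one so far where one change has moved the number, though only modestly. Nothing measured here explains the step.

On these data alone, whether the step reflects fluoro entering or ethyl leaving stays open, as only these two groups can be compared directly at this position. Also open, as far as these compounds go, are how an amine or a longer chain would behave here, and whether the step would hold with 4-chlorophenyl on the amide-type nitrogen.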